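Notes on the step from compound 2 to compound 3

The source may report more compounds than this note shows. Statements on the series, on what has been measured and on what is new or still open speak of the compounds shown alone.

Measured so far in a functional assay on HCT-116 cells (Homo sapiens) for antiproliferative activity, read by MTT assay, with a stated time of 24 h (a lower number here means a stronger inhibitor, a higher number a weaker inhibitor), on this series:
- compound 1 `COc1ccccc1/C=C/C(=O)c1ccc(OC)c2c1OC(C)(C)C=C2` gives > 10000 nM (a limit)
- compound 2 `COc1ccc(C(=O)/C=C/c2cccc(O)c2)c2c1C=CC(C)(C)O2` gives > 10000 nM (a limit)

Compound 2 stands at > 10000 nM as a limit, which offers no number to start from and is the only anchor for an estimate. All the series shows so far is the limit of > 10000 nM in this assay, at which 2 of the 2 values shown sit, and nothing finer. Among the measured compounds shown here, the one measured step is a step that the two limits leave unreadable from compound 1 to compound 2 and so sets neither a size nor a direction. The change now is 3-bromo-4-hydroxyphenyl in place of 3-hydroxyphenyl on a double-bonded chain carbon bound to a double-bonded chain carbon and leads to compound 3 `COc1ccc(C(=O)/C=C/c2ccc(O)c(Br)c2)c2c1C=CC(C)(C)O2` with 3-bromo-4-hydroxyphenyl in place of 3-hydroxyphenyl on a double-bonded chain carbon bound to a double-bonded chain carbon. In this assay, as far as these compounds go, the expected step is a number no higher from compound 2 to compound 3 (the limit leaves the size open) and its direction stays open. The estimate for compound 3 is 10000 nM with an expected range of 2500 nM to 30000 nM for this measurement.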

Compound 3, half-maximal inhibitory concentration: > 10000 nM
Compound 3: only a limit was reported; the forecaster's own chance of this, stated with the estimate: 55%; the middle value sits exactly at the limit.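

No new step can be read among compound 1, compound 2 and compound 3, since each is reported only as a limit: the limit of > 10000 nM in this assay, at which 3 of the 3 values shown sit.

In this assay the compounds shown leave open how far each lies from that limit, and whether the groups exchanged on the double-bonded chain carbon differ at all.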